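The compounds below may be only part of what the source reports. "The series", "measured", "known", "first", "only" and "open" are said of these compounds alone.

Compound 2 `Nc1nc(N)nc(-c2cccc(Br)c2)n1` stands highest of the two numbers in a functional assay on the whole organism with Rattus norvegicus as the target, at a dose of 20 mg/kg by the intraperitoneal route; a lower number here means less inhibition, a higher number more inhibition at the dose given (going by the name of the read-out): compound 2 gives 96%, while compound 1 `Nc1nc(N)nc(-c2cccc(F)c2)n1` gives 70%. Among the compounds with values here, the single measured step, a number 26 percentage points higher from compound 1 to compound 2 (beyond the scatter), came with bromo in place of fluoro on an aromatic carbon. Compound 3 `Nc1nc(N)nc(-c2cccc(Cl)c2)n1` differs from compound 2 by chloro in place of bromo on an aromatic carbon. Within the data shown here, only that one halogen-for-halogen step bears on this change, and it was modest, so a modest fall, smaller than that step, is expected in this assay. For compound 3 the estimate is 88%, with a range from 72% to 98%. The expected step is a number 8 percentage points lower from compound 2 to compound 3 (within the scatter).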

Compound 3, a percentage reported as inhibition, in the whole organism at one dose (the size of the read-out at that dose, not a potency): 100%
Estimate against measurement, compound 3: 12 percentage points below, outside the stated range (above it).
By their numbers in this assay, from the lowest: compound 1; then compounds 2 and 3 (each within the scatter of the next).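

In this assay, chloro and bromo at this position do not separate, with a number 4 percentage points higher from compound 2 to compound 3 (within the scatter). Chloro in place of fluoro gives a number 30 percentage points higher from compound 1 to compound 3 (beyond the scatter), so both larger halogens stand clear of fluoro, not bromo alone. Nothing available explains this split between fluoro and the other two halogens.

Whether this position needs a halogen at all stays open, since the compounds shown carry only fluoro, chloro or bromo there; an amine, a methoxy group or a nitrile in the same place would test that. A reading at one dose also leaves the potency of compound 2 and compound 3 unresolved.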